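The source may hold more compounds than are shown below. What is called first, only, known or untested is meant among the compounds shown, and "the series" means these compounds.

Compound 1 `Oc1cccc(-c2cc(-c3cccnc3)nc(-c3cccc(Cl)c3)c2)c1`: "not determined" (no result reported)
Compound 2 `Oc1cccc(-c2cc(-c3cccc(Cl)c3)nc(-c3ccccn3)c2)c1`: "not determined" (no result reported)
Compound 3 `Oc1cccc(-c2cc(-c3cccc(Cl)c3)nc(-c3ccco3)c2)c1`: 3570 nM

Three compounds share one core, and each carries a different ring on it. In a functional assay on T47D cells (Homo sapiens) for cytotoxicity, read by CCK-8 assay and cell counting, with a stated time of 2 days (a higher number here means a weaker inhibitor, a lower number a stronger inhibitor), compound 1 has no reported result, and compound 2 likewise has no reported result. Going by the values given here, compound 3 gives 3570 nM in this assay, and this is the only number in hand, so there is nothing yet to set it against and no step between measured compounds can be drawn.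

Compound 4 `Oc1cccc(-c2cc(-c3ccc(Cl)cc3)nc(-c3ccco3)c2)c1` differs from compound 3 in a single place: 4-chlorophenyl in place of 3-chlorophenyl on an aromatic carbon. The two have the same atoms, joined differently. Among the compounds with values here, no measured pair shows what such a change does. With the same atoms kept and only their arrangement altered, the step in this assay is expected to stay within the usual scatter, in no particular direction, as a 1.0-fold lower number from compound 3 to compound 4 (0.01 log units; within the scatter). Compound 4 is therefore estimated at 3500 nM, within a range from 1200 nM to 10000 nM.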

Compound 4, half-maximal inhibitory concentration: 10500 nM
The estimate for compound 4 lay 3.0-fold (0.48 log units) below the measured number; the measured number lies above the stated range.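

In this assay, going by these compounds alone, moving the chlorine from 3-chlorophenyl to 4-chlorophenyl gives a 2.9-fold higher number from compound 3 to compound 4 (0.47 log units; beyond the scatter), the first step that can be read, and it makes the compound a weaker inhibitor. The two groups have the same atoms and differ only in where the chlorine sits, so this position on the shared core responds to a change in arrangement alone, by more than the usual scatter. Nothing available explains why the 4-chlorophenyl form is weaker.

Two positions of one chlorine say little about the wider range of groups that this site might accept. From the compounds shown here alone, whether an amine or a carboxylic acid in place of the chlorine would bring the number down or push it up remains open, and so does the effect of a methoxy group at either of these two ring positions.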